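Cytotoxicity notes on a chalcone series: methoxy to fluoro

The source may hold more compounds than are shown below. What is called first, only, known or untested is meant among the compounds shown, and "the series" means these compounds.

Measured so far:
compound 1, `COc1cccc(/C=C/C(=O)c2cc(NC(C)=O)ccc2O)c1`: 40000 nM
compound 2, `COc1ccc(/C=C/C(=O)c2cc(NC(C)=O)ccc2O)cc1`: 38700 nM

Two compounds have been run in an ADME assay on MT4 cells (Homo sapiens) for cytotoxicity, read by MTT assay, with a stated time of 4 days; a higher number here means that more compound is tolerated, a lower number that less compound is tolerated. Compound 1 gives 40000 nM, and compound 2 gives 38700 nM. The gap between the two is within the scatter of this assay, so compound 1 cannot be placed above or below compound 2; both sit at the same level of tolerated concentration. Among the compounds with values here, no step between measured compounds that differ in one place is available.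

Compound 3, `CC(=O)Nc1ccc(O)c(C(=O)/C=C/c2cccc(F)c2)c1`, is not yet measured in this assay. Compared with compound 1 the change is fluoro in place of methoxy on an aromatic carbon. With only compound 1 and compound 2 as reference, and both at one level, no step beyond the scatter is expected in either direction. For compound 3 the expected result is 40000 nM, within 15000 nM to 100000 nM, which means an estimated step of no change at the digits printed from compound 1 to compound 3 (within the scatter) of no real size.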

Compound 3, half-maximal cytotoxic concentration: 30100 nM
Compound 3: middle estimate off by 1.3-fold (0.12 log units), on the high side; low and high end bracket the measured number.
By their numbers in this assay, from the lowest: compounds 3, 2 and 1 (each within the scatter of the next).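

In this assay fluoro in place of methoxy on an aromatic carbon, meta to a large group, gives a 1.3-fold lower number from compound 1 to compound 3 (0.12 log units; within the scatter) and so keeps compound 3 at the level of compound 1. Within the data shown here, this is the first one-place step: the methoxy, with 2 heavy atoms and 1 hydrogen-bond acceptor, gives way to the fluoro, with 1 heavy atom and 0 hydrogen-bond acceptors, and no step beyond the scatter appears at this position. No measurement bears on why the level holds through this change.

The compounds shown leave open whether an amine or a carboxylic acid on this aromatic carbon would stay at the same level. They also leave open whether fluoro in place of the methoxy of compound 2 would give a step of similar size.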